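This account rests on a few compounds, and the source may have more. Where it says the series, first, only, none or still open, it means among the compounds named here.

Measured in an in vitro ADME assay on microsomes from Gut (Homo sapiens) for metabolic stability, using NADPH; a lower number here means slower removal, a higher number faster removal of the compound:
- Compound 1 `CC(C)(CO)CNC(=O)c1cc2cc(C#N)ccc2n1Cc1cc(Cl)cc(Cl)c1`: < 6 mL.min-1.g-1 (a limit, not a number)
- Compound 2 `Cc1ccc(F)cc1Cn1c(C(=O)NCC2(CO)CCC2)cc2cc(C#N)ccc21`: < 6 mL.min-1.g-1 (a limit, not a number)
- Compound 3 `CC(C)(O)CCNC(=O)c1cc2cc(C#N)ccc2n1Cc1cccc(OC(F)(F)F)c1`: < 6 mL.min-1.g-1 (a limit, not a number)

Compound 3 sits at < 6 mL.min-1.g-1, which is a limit of the assay and not a number. The wider picture is the same: the limit of < 6 mL.min-1.g-1 in this assay, at which 3 of the 3 values shown sit. Among the measured compounds shown here, no measured compound therefore gives a number to rank against.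

Compound 4 `N#Cc1ccc2c(c1)cc(C(=O)NCCC(O)C(F)(F)F)n2Cc1cccc(OC(F)(F)F)c1` keeps the rest of compound 3 but carries 2,2,2-trifluoro-1-hydroxyethyl in place of 1-hydroxy-1-methylethyl on a saturated chain carbon, two bonds along the chain from an amide-type nitrogen.

For the measured compounds named here, no measured pair differs in one place only, so this change has no direct precedent. The expectation rests on (the limit of < 6 mL.min-1.g-1 in this assay, at which 3 of the 3 values shown sit), which holds across differing amide chains in compounds 1, 2 and 3. The expected step, a step that the limit leaves unreadable from compound 3 to compound 4, is none beyond the scatter, and another limit is the likeliest report in this assay. For compound 4 the estimated value is 5 mL.min-1.g-1, with an expected range of 3 mL.min-1.g-1 to 11 mL.min-1.g-1.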

Compound 4, intrinsic clearance in microsomes: 26 mL.min-1.g-1
The estimate for compound 4 lay 5.2-fold (0.72 log units) below the measured number, and the stated range ends below it.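

In this assay, 2,2,2-trifluoro-1-hydroxyethyl in place of 1-hydroxy-1-methylethyl, on a saturated chain carbon two bonds along the chain from an amide-type nitrogen, gives an at least 4.3-fold higher number from compound 3 to compound 4 (0.63 log units; beyond the scatter). This is the first sign that a single change on the amide chain can lift a compound off the floor of this read-out, and compound 4 is the only compound shown with a number rather than a limit. The earlier compounds could not show this, as differing amide chains gave one and the same reading: the limit of < 6 mL.min-1.g-1 in this assay, at which 3 of the 4 values shown sit.

As far as these compounds go, the true size of the step stays open, since its starting point is a limit. Also open, from the compounds shown here alone, is how an amine or a carboxylic acid at this place on the chain would read in this assay, and whether the same change would give a step on the benzyl groups of compound 1 or compound 2.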